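Swapping 2,6-Dimethoxyphenyl for 2,4-Dichlorophenyl

The compounds below may be only part of what the source reports. "The series", "measured", "known", "first", "only" and "open" are said of these compounds alone.

Compound 1 `O=C(Cc1csc2nc(-c3ccc(Br)cc3)cn12)N/N=C/c1ccccc1`: > 100000 nM
Compound 2 `O=C(Cc1csc2nc(-c3ccc(Br)cc3)cn12)N/N=C/c1ccc(O)cc1`: 23400 nM
Compound 3 `COc1cccc(OC)c1/C=N/NC(=O)Cc1csc2nc(-c3ccc(Br)cc3)cn12`: 72400 nM

In a functional assay on M14 cells (Homo sapiens) for inhibition, read by sulforhodamine B assay, with a stated time of 48 h (on this read-out higher numbers stand for weaker inhibition of growth and lower numbers for stronger inhibition of growth), compound 1 gives > 100000 nM as a limit of the assay and not a number.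

Compound 3 gives 72400 nM and holds the higher of the two true numbers (a 3.1-fold higher number from compound 2 to compound 3 (0.49 log units; beyond the scatter)).

Compound 4 `O=C(Cc1csc2nc(-c3ccc(Br)cc3)cn12)N/N=C/c1ccc(Cl)cc1Cl` carries 2,4-dichlorophenyl in place of 2,6-dimethoxyphenyl on a carbon with a double bond to nitrogen.

For the measured compounds named here, two measured steps bear on this. The hydroxy change (an at least 4.2-fold lower number from compound 1 to compound 2 (0.63 log units; beyond the scatter)) lies beyond the scatter, whereas the 2,6-dimethoxyphenyl change (an at least 1.3-fold lower number from compound 1 to compound 3 (0.14 log units; that floor lies within the scatter)) has a floor within it. Compound 4 gains no hydroxy group, so no step beyond the scatter is expected in this assay.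

The expected change is small (a 1.2-fold lower number from compound 3 to compound 4 (0.08 log units; within the scatter)).

For compound 4 the estimated value is 60000 nM (expected range 20000 nM to 100000 nM).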

Compound 4, concentration for total growth inhibition: > 100000 nM
Compound 4 ended at the assay's limit; the forecaster's own chance of this, stated with the estimate: 30%; middle value at least 1.6-fold (0.22 log units) from the limit.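

On this carbon, 2,4-dichlorophenyl in place of 4-hydroxyphenyl weakens growth inhibition in this assay, with an at least 4.2-fold higher number from compound 2 to compound 4 (0.63 log units; beyond the scatter). Against 2,6-dimethoxyphenyl, the change gives an at least 1.3-fold higher number from compound 3 to compound 4 (0.14 log units; that floor lies within the scatter), so no real difference between these two groups is established. The step between compound 1 and compound 4 cannot be read, as each value is a limit of the assay and not a number: the limit of > 100000 nM in this assay, at which 2 of the 4 values shown sit.

Still open, on these data alone, is whether the gain seen with compound 2 is specific to the hydroxy group. A 4-aminophenyl or 4-carboxyphenyl group on this carbon would help to answer that.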